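The source may hold more compounds than are shown below. What is called first, only, known or untested is meant among the compounds shown, and "the series" means these compounds.

Measured in a functional assay on DU-145 cells (Homo sapiens) for cytotoxicity, read by MTT assay, with a stated time of 48 h; on this read-out lower numbers stand for stronger inhibition and higher numbers for weaker inhibition:
Compound 1 `C=C(c1ccc(OC)cc1)c1cc(OC)c(OC)c(OC)c1-c1ccccc1`: 8000 nM
Compound 2 `C=C(c1ccc(OC)cc1)c1cc(OC)c(OC)c(OC)c1-c1ccc2ccccc2c1`: 46000 nM

Of these two, compound 1 holds the lower number, 8000 nM, and so shows the stronger inhibition in this assay. The next compound to be tested is compound 3 `C=C(c1ccc(C(F)(F)F)cc1)c1cc(OC)c(OC)c(OC)c1-c1ccccc1`, which keeps the core of compound 1 but carries trifluoromethyl in place of methoxy on an aromatic carbon, para to a large group: trifluoromethyl in place of methoxy on an aromatic carbon. In other words, 4-methoxyphenyl becomes 4-(trifluoromethyl)phenyl. For the measured compounds named here, no measured step touches this position. Going by the values given here, the only guide is a 5.8-fold higher number from compound 1 to compound 2 (0.76 log units; beyond the scatter), which came from naphthalen-2-yl in place of phenyl at a different place on the molecule, so it bears on this change only loosely. It does show that a single change to compound 1 can move the number by a modest amount, and here it moved upward. A step of similar modest size toward a higher number is therefore expected, although the data do not settle the direction. The expected change is a 2.5-fold higher number from compound 1 to compound 3 (0.40 log units; beyond the scatter). For compound 3 the estimated value is 20000 nM, with an expected range from 6000 nM to 60000 nM.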

Compound 3, half-maximal inhibitory concentration: 31000 nM
Estimate against measurement, compound 3: 1.6-fold (0.19 log units) below; the range from low to high includes it.
By their numbers in this assay, from the lowest: compound 1; then compounds 3 and 2 (each within the scatter of the next).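

In this assay, for the compounds shown here, the change from 4-methoxyphenyl to 4-(trifluoromethyl)phenyl gives a 3.9-fold higher number from compound 1 to compound 3 (0.59 log units; beyond the scatter), so this place on the molecule, which no earlier step had touched, does respond to a single change, and of the two groups seen here methoxy goes with the lower number. Methoxy, the group that leaves, counts a hydrogen-bond acceptor while trifluoromethyl counts none, but this single pair of compounds cannot separate that difference from the other differences between the two groups. No measurement at hand accounts for the direction or the size of this step.

The compounds shown leave open how other groups at this place would read, such as a hydroxyl, an amine or a single chlorine atom, and whether any of them would bring the number below that of compound 1. They also leave open whether the trifluoromethyl change would act in the same way on a compound carrying naphthalen-2-yl in place of phenyl.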